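Trifluoromethoxy analogue with para-hydroxyphenyl: an expectation

A few compounds are considered here, and "the series" means these few. Any claim that something is new, unique, unknown or untested is made for them only; others in the source may bear on it.

The series shares one core, seen in compound 1 `Oc1ccc(-c2cc(-c3ccc(F)cc3)cc(-c3ccc(O)cc3)n2)cc1`. In a functional assay on HCT-15 cells (Homo sapiens) for inhibition (on this read-out higher numbers stand for weaker inhibition and lower numbers for stronger inhibition), compound 1 gives 4970 nM. Compound 2 `Oc1ccc(-c2cc(-c3ccc(C(F)(F)F)cc3)cc(-c3ccccc3O)n2)cc1` carries a trifluoromethyl group and a 2-hydroxyphenyl; in this assay compound 2 reaches only a limit, > 50000 nM. Compound 3 `Oc1ccc(-c2cc(-c3ccc(OC(F)(F)F)cc3)cc(-c3ccccc3O)n2)cc1` likewise stands at a limit in this assay, > 50000 nM. For the measured compounds named here, the one measured step, a step that the two limits leave unreadable from compound 2 to compound 3, cannot be read, because both of its ends sit at the limit of > 50000 nM in this assay, at which 2 of the 3 values shown sit. Compound 4 `Oc1ccc(-c2cc(-c3ccc(OC(F)(F)F)cc3)cc(-c3ccc(O)cc3)n2)cc1` differs from compound 3 by 4-hydroxyphenyl in place of 2-hydroxyphenyl on an aromatic carbon. Going by the values given here, no measured pair differs in that place alone, so no step bears directly on it; compound 1, the only compound with a numeric value, also carries a 4-hydroxyphenyl, but with a fluoro substituent elsewhere, and compound 2 and compound 3 show only that the 2-hydroxyphenyl compounds sit at the limit. Compound 4 is therefore expected to fall between the limit and the value of compound 1, at 15000 nM, within 3000 nM to 50000 nM; the implied step an at least 3.3-fold lower number from compound 3 to compound 4 (0.52 log units; beyond the scatter) is an estimate, not a reading.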

Compound 4, half-maximal inhibitory concentration: 13900 nM
Compound 4: the middle estimate sits 1.1-fold (0.03 log units) above what was measured; the measured number falls inside the stated range.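

The swap changes no atoms, only how they are joined, yet in this assay 4-hydroxyphenyl in place of 2-hydroxyphenyl, on the aromatic carbon next to the ring nitrogen, brings an at least 3.5-fold lower number from compound 3 to compound 4 (0.55 log units; beyond the scatter). For the compounds shown here, this is the first readable change at this position, and it shows that the place of the hydroxyl on this ring separates a measurable value from none. With 4-hydroxyphenyl held fixed, trifluoromethoxy in place of fluoro then gives a 2.8-fold higher number from compound 1 to compound 4 (0.45 log units; beyond the scatter), so the other substituent also moves the number, and the first step can be stated only as a bound, since compound 3 stands at a limit: the limit of > 50000 nM in this assay, at which 2 of the 4 values shown sit.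

From the compounds shown here alone, how far the 2-hydroxyphenyl compounds really lie from compound 4 stays unknown. Going by these compounds, it is also open whether an aminophenyl or a methoxyphenyl at this position would match 4-hydroxyphenyl, or whether a free hydroxyl is needed there at all.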